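The source may report more compounds than this note shows. Statements on the series, on what has been measured and on what is new or still open speak of the compounds shown alone.

The study compares a set of bis-benzylidene cyclohexanones that carry methoxy groups on their outer aromatic rings. Compound 1 `COc1ccccc1/C=C1\CCC/C(=C\c2ccc(OC)c(OC)c2)C1=O` is the reference; in a functional assay on SW-620 cells (Homo sapiens) for cytotoxicity, read by MTT assay, with a stated time of 72 h (on this read-out higher numbers stand for weaker inhibition and lower numbers for stronger inhibition), compound 1 gives 7800 nM. Compound 2 `COc1ccc(/C=C2\CCC/C(=C\c3ccc(OC)c(OC)c3)C2=O)c(OC)c1` differs from it by a single change, (methoxy in place of hydrogen on an aromatic carbon). For compound 2 the measurement in this assay reaches only a limit of the method, > 20000 nM, and the step of an at least 2.5-fold higher number from compound 1 to compound 2 (0.40 log units; beyond the scatter) is therefore read from a limit, (the limit of > 20000 nM in this assay, at which 1 of the 3 values shown sits).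

Compound 3 `COc1cc(/C=C2\CCC/C(=C\c3ccc(OC)c(OC)c3)C2=O)cc(OC)c1` stands on another core; how the cores of compound 3 and compound 1 differ is not broken down here. In this assay compound 3 gives 2500 nM, which is the lower of the two numbers measured, with compound 1 the nearer of the two.

Compound 4 `COc1ccc(/C=C2\CCC/C(=C\c3cc(OC)c(OC)c(OC)c3)C2=O)cc1OC` has not yet been measured in this assay. It is reached from compound 3 by methoxy in place of hydrogen on an aromatic carbon. Among the compounds with values here, this is the same kind of change as the one from compound 1 to compound 2, not the same change: there the entering methoxy sat meta to a methoxy group, here it sits ortho to two methoxy groups, in both cases para to a large group. Since the earlier step weakened inhibition, the step of a 2.8-fold higher number from compound 3 to compound 4 (0.45 log units; beyond the scatter) is expected to run in the same direction, though its size is uncertain because the step of an at least 2.5-fold higher number from compound 1 to compound 2 (0.40 log units; beyond the scatter) is itself only a lower bound. Compound 4 is estimated to give 7000 nM in this assay, within a range from 2500 nM to 20000 nM.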

Compound 4, half-maximal inhibitory concentration: 1800 nM
For compound 4 the middle estimate is 3.9-fold (0.59 log units) above the measured one, and the stated range ends above it.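

In this assay the new step is a 1.4-fold lower number from compound 3 to compound 4 (0.14 log units; within the scatter), so on this core the entering methoxy group leaves the reading within the scatter, whereas the same kind of change on the core of compound 1 weakened inhibition. Set side by side, the two steps show that this change does not carry over unchanged from one core to the other in this series: the same change on two cores in this assay, an at least 2.5-fold higher number (0.40 log units; beyond the scatter) from compound 1 to compound 2 and a 1.4-fold lower number (0.14 log units; within the scatter) from compound 3 to compound 4, at least 3.5-fold (0.55 log units) apart, beyond the scatter of two such steps This holds for these two pairs only and does not show what lies behind the difference, and the true size of the earlier step stays unknown, as the reading for compound 2 is a limit of the assay and not a number: the limit of > 20000 nM in this assay, at which 1 of the 4 values shown sits.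

The compounds shown carry only methoxy groups on their outer aromatic rings, which leaves open whether a hydroxyl group, a fluorine atom or an amine on the same aromatic carbon would follow the step seen on the core of compound 1 or the one seen on the core of compound 3. They also leave open how the methoxy change itself would behave on a third core, and therefore whether either of the two results is the more typical one for this series.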